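This account rests on a few compounds, and the source may have more. Where it says the series, first, only, none or still open, it means among the compounds named here.

Measured so far in a physicochemical assay for solubility, in phosphate buffer, at pH 7.4; a higher number here means a more soluble compound, a lower number a less soluble compound:
- compound 1 `OCC1CCN(c2nccnc2OC2CN(c3ccc4ccccc4n3)C2)C1`: 167000 nM
- compound 2 `OCc1cccc(-c2nccnc2OC2CN(c3ccc4ccccc4n3)C2)c1`: 29000 nM

Of these two, compound 2 has the lower number, at 29000 nM. The next compound, compound 3 `Cc1ccc(-c2nccnc2OC2CN(c3ccc4ccccc4n3)C2)cc1`, differs from compound 2 in one place, with 4-methylphenyl in place of 3-(hydroxymethyl)phenyl on an aromatic carbon.

Going by the values given here, only one measured step bears on this change. It is a 5.8-fold lower number from compound 1 to compound 2 (0.76 log units; beyond the scatter), a modest step beyond the scatter, made at the same place on the shared core. Among the compounds with values here, that step is only indirect evidence, since both of its compounds carry a hydroxymethyl group and no measured pair shows what losing that group does. The expectation therefore rests on thin ground. A further fall of similar size is expected, and the estimate is a 4.1-fold lower number from compound 2 to compound 3 (0.62 log units; beyond the scatter). The range is kept wide, as a single step is all there is to go on. For compound 3 the expected value is 7000 nM, with an estimated range from 1500 nM to 25000 nM.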

Compound 3, solubility: < 1000 nM
Compound 3 gave a limit, no number (the forecaster's own chance of this, stated with the estimate: 5%); middle value at least 7.0-fold (0.84 log units) away from the limit.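

In this assay compound 3 gives a limit and no number: the limit of < 1000 nM in this assay, at which 1 of the 3 values shown sits.

Going by these compounds alone, the change at this aromatic carbon, next to the ring nitrogen, from 3-(hydroxymethyl)phenyl to 4-methylphenyl is an at least 29-fold lower number from compound 2 to compound 3 (1.46 log units; beyond the scatter), a large step, whereas the only earlier step at this place was modest. Set against the 3-(hydroxymethyl)pyrrolidin-1-yl group, 4-methylphenyl gives an at least 160-fold lower number from compound 1 to compound 3 (2.22 log units; beyond the scatter), so the choice of group at this one place, with the rest of the shared core unchanged, spans a wide range of this assay, and the true size of that range remains hidden behind the limit.

The change from compound 2 to compound 3 replaces hydroxymethyl with methyl and also moves the substituent around the phenyl ring, and the compounds shown do not separate these two differences. Also open, on these data alone, is where a phenyl ring carrying an amine or a carboxylic acid, or a longer chain ending in a hydroxyl group, would fall relative to compound 2 and compound 3.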